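Taking the chloro group off compound 2

The compounds below may be only part of what the source reports. "The series", "measured", "known", "first", "only" and "open" are said of these compounds alone.

Measured so far in a functional assay on MCF7 cells (Homo sapiens) for inhibition, read by fluorescence, with a stated time of 72 h; on this read-out lower numbers stand for stronger inhibition of growth and higher numbers for weaker inhibition of growth:
- compound 1 `COc1ccc(Nc2nc(N[C@H]3CC[C@H](N)CC3)nc3c2ncn3CCC(C)C)c(OC)c1` with 6300 nM
- compound 2 `CC(C)CCn1cnc2c(Nc3cccc(Cl)c3)nc(N[C@H]3CC[C@H](N)CC3)nc21` with 2100 nM

Compound 2 holds the lower of these two numbers in this assay and is the stronger inhibitor of growth. Compound 3 `CC(C)CCn1cnc2c(Nc3ccccc3)nc(N[C@H]3CC[C@H](N)CC3)nc21` differs from it by hydrogen in place of chloro on an aromatic carbon with hydrogen in place of chloro on an aromatic carbon. Among the compounds with values here, one measured step bears on this, a 3.0-fold lower number from compound 1 to compound 2 (0.48 log units; beyond the scatter) where 3-chlorophenyl replaced 2,4-dimethoxyphenyl on a nitrogen on an aromatic ring. That modest step does not isolate the chloro group, so only a small rise is expected, an estimated 1.4-fold higher number from compound 2 to compound 3 (0.15 log units; within the scatter) on this read-out. Compound 3 is expected at 3000 nM within an estimated range of 1200 nM to 7500 nM in this measurement.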

Compound 3, concentration for 50% growth inhibition: 5400 nM
Estimate against measurement, compound 3: 1.8-fold (0.26 log units) below, and the stated range covers the measured number.
By their numbers in this assay, from the lowest: compound 2; then compounds 3 and 1 (each within the scatter of the next).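

In this assay taking off the chloro group alone gives a 2.6-fold higher number from compound 2 to compound 3 (0.41 log units; beyond the scatter) and so shows that this one atom on the aromatic carbon carries a step beyond the scatter. Without it, phenyl and 2,4-dimethoxyphenyl show a 1.2-fold lower number from compound 1 to compound 3 (0.07 log units; within the scatter) within the scatter, which ties the edge of compound 2 over compound 1 to the chloro group and not to the absence of the methoxy groups. Nothing measured here gives a cause for this step.

As far as these compounds go, whether fluoro, bromo, methyl or trifluoromethyl at this place would match chloro stays open.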